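The compounds below may be only part of what the source reports. "The series", "measured", "known", "first", "only" and "open" are said of these compounds alone.

Measured compounds:
compound 1, `COc1ccc(-c2cc(/C=C/C(=O)c3ccc(N)cc3)[nH]n2)cc1`, 95%
compound 2, `COc1ccc(-c2cc(/C=C/C(=O)c3ccc(N)cc3)[nH]n2)cc1OC`, 100%
compound 3, `COc1cc(C(=O)/C=C/c2cc(-c3cc(OC)c(OC)c(OC)c3)n[nH]2)cc(OC)c1OC`, 99%

In a functional assay on SF-268 cells (Homo sapiens) for cytotoxicity, read by sulforhodamine B assay, with a stated time of 48 h, tested at 0.01 uM (on this read-out higher numbers stand for a weaker effect at the one concentration tested and lower numbers for a stronger effect), all three measured compounds give numbers of the same size. The change hydrogen in place of methoxy on an aromatic carbon gave a number 5 percentage points lower from compound 2 to compound 1 (within the scatter). The difference between the cores of compound 2 and compound 3 is not broken down here. Compound 4, `COc1ccc(-c2cc(/C=C/C(=O)c3cc(OC)c(OC)c(OC)c3)[nH]n2)cc1OC`, is derived from compound 3 by hydrogen in place of methoxy on an aromatic carbon, the same kind of change as that from compound 2 to compound 1, although here the place is also meta to a methoxy group. The expected step is a number 2 percentage points lower from compound 3 to compound 4 (within the scatter), which rests on the earlier step being within the scatter, a number 5 percentage points lower from compound 2 to compound 1 (within the scatter). Compound 4 is therefore expected to give 97% in this assay, with a range estimated from 86% to 103%.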

Compound 4, a percentage reported as activity, at one concentration (the size of the read-out at that concentration, not a potency): 99%
For compound 4 the middle estimate is 2 percentage points below the measured one; low and high end bracket the measured number.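

In this assay, putting hydrogen in place of methoxy on an aromatic carbon gave no change at the digits printed from compound 3 to compound 4 (within the scatter). Carried from one core to the other, the change gives steps that cannot be told apart: the same change on two cores in this assay, a number 5 percentage points lower (within the scatter) from compound 2 to compound 1 and no change at the digits printed (within the scatter) from compound 3 to compound 4, 5 percentage points apart, within the scatter of two such steps. Going by these compounds alone, this shows only that neither step stands out from the scatter at the one concentration tested; it does not show that the change would transfer between these cores where a clear effect could be read, as neither step here shows one.

The compounds shown leave open how other groups in that place, such as a hydroxyl or a chlorine, would read. They also leave open how the change would read at other concentrations.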